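This account rests on a few compounds, and the source may have more. Where it says the series, first, only, none or still open, it means among the compounds named here.

Within the data shown here, compound 1 `O=c1c2ccccc2c(Cc2ccc(Cl)cc2)nn1CCNCCCCc1ccc(OCCCN2CCCCCC2)cc1` is measured in an assay for binding affinity to Alpha-1B adrenergic receptor (Homo sapiens) (a lower number here means a stronger inhibitor, a higher number a weaker inhibitor), at 316 nM, the highest of the two numbers so far. Compound 2 `CN1CCC[C@@H]1Cn1nc(CCc2ccccc2)c2ccccc2c1=O` gives 200 nM in this assay, a value that lies within the scatter of compound 1. Compound 3 `CN(CCCCc1ccc(OCCCN2CCCCCC2)cc1)CCn1nc(Cc2ccc(Cl)cc2)c2ccccc2c1=O` differs from compound 1 by methyl in place of hydrogen on an amine nitrogen. Among the measured compounds shown here, no step between two measured compounds is available, so nothing in the data points in either direction. The step from compound 1 to compound 3 in this assay is expected to stay within the scatter, a 1.1-fold lower number from compound 1 to compound 3 (0.02 log units; within the scatter). Compound 3 is therefore estimated at 300 nM, between 100 nM and 1000 nM.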

Compound 3, inhibition constant: > 1990 nM
Compound 3: no number, only a limit; the forecaster's own chance of this, stated with the estimate: 5%; middle value at least 6.6-fold (0.82 log units) from the limit.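

In this assay, among these compounds, the amine nitrogen in the chain of compound 1 turns out not to tolerate every change: this is the first step that can be read, and methyl in place of hydrogen gives an at least 6.2-fold higher number from compound 1 to compound 3 (0.79 log units; beyond the scatter). For compound 3 the reading is a limit of the assay and not a number, so the full size of the step stays unknown: the limit of > 1990 nM in this assay, at which 1 of the 3 values shown sits.

From the compounds shown here alone, whether ethyl or an acetyl group on this nitrogen would act as methyl does remains open. The compounds shown also leave open whether the same change would have this result on a shorter chain.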